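From pyrazine to pyridine at a cytotoxicity limit

The compounds below may be only part of what the source reports. "The series", "measured", "known", "first", "only" and "open" are said of these compounds alone.

Compound 2 `CC/C(=N\NC(=O)c1cnccn1)c1ccccc1O` was tested in a toxicity assay (H9c2 cells) for cytotoxicity, with Rattus norvegicus as the target, read by neutral red uptake, with a stated time of 72 h (on this read-out lower numbers stand for stronger inhibition and higher numbers for weaker inhibition), where compound 2 gives > 100000 nM, a limit of the assay rather than a number. For the measured compounds named here, compound 1 `C/C(=N\NC(=O)c1cnccn1)c1ccccc1O` gives 41200 nM, and the only measured step is an at least 2.4-fold higher number from compound 1 to compound 2 (0.38 log units; beyond the scatter), which concerns the chain. Compound 3 `CC/C(=N\NC(=O)c1cccnc1)c1ccccc1O` differs from compound 2 by pyridin-3-yl in place of pyrazin-2-yl on a carbonyl carbon. Going by the values given here, no measured step bears on that change, so no shift beyond the scatter is expected, and the estimated step of a number no higher from compound 2 to compound 3 (the limit leaves the size open) is taken as none. Compound 3 is therefore expected near 100000 nM, between 40000 nM and 250000 nM, with a limit again likely.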

Compound 3, half-maximal inhibitory concentration: 7100 nM
The estimate for compound 3 lay 14-fold (1.15 log units) above the measured number; the whole stated range lies above it.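

The change from pyrazin-2-yl to pyridin-3-yl on a carbonyl carbon gives an at least 14-fold lower number from compound 2 to compound 3 (1.14 log units; beyond the scatter) in this assay, so this position carries a large shift of its own, which the earlier step on the chain could not show. Going by these compounds, its full size stays open because compound 2 stands at a limit, not a number: the limit of > 100000 nM in this assay, at which 1 of the 3 values shown sits.

The compounds shown leave open what a phenyl or pyridin-4-yl group at this place would give. They also leave open whether pyridin-3-yl would bring a similar shift with the shorter chain of compound 1 or with a longer chain.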